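Swapping Formyl for Cyano in a Cytotoxicity Series

This account rests on a few compounds, and the source may have more. Where it says the series, first, only, none or still open, it means among the compounds named here.

In a toxicity assay on A549 cells (Homo sapiens) for cytotoxicity, read by CCK-8 assay (on this read-out higher numbers stand for lower toxicity in this test and lower numbers for higher toxicity in this test), compound 1 (`COc1cccc2[nH]c(C(=O)N[C@@H](CC(C)C)C(=O)N[C@H](C=O)C[C@@H]3CCNC3=O)cc12`) gives > 200000 nM as its reading, which is a limit of the assay and not a number. Compound 1 thus stands at the limit of > 200000 nM in this assay, at which 2 of the 3 values shown sit, in this small set. Compound 2 (`COc1cc(Cl)cc2[nH]c(C(=O)N[C@@H](CC(C)(C)C)C(=O)N[C@H](C#N)C[C@@H]3CCCNC3=O)cc12`), which carries a cyano group, reads > 200000 nM in this assay as its result, and this too is a limit. Compound 3 (`CC(C)C[C@H](NC(=O)c1cc2c(OC(F)(F)F)cccc2[nH]1)C(=O)N[C@H](C#N)C[C@@H]1CCCNC1=O`), also a cyano compound, gives a true number, 90000 nM, in this assay as well.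

Compound 4 (`COc1cccc2[nH]c(C(=O)N[C@@H](CC(C)C)C(=O)N[C@H](C#N)C[C@@H]3CCNC3=O)cc12`) keeps the core of compound 1 and has cyano in place of formyl on a saturated chain carbon bound to an amide-type nitrogen and a saturated chain carbon. Among the measured compounds shown here, no measured pair in the set isolates this change. The expectation in this assay is therefore for no step beyond the scatter, or at most a small one toward lower numbers, with compound 3 reading 90000 nM on the same scale while also carrying cyano. The expected change is a number no higher from compound 1 to compound 4 (the limit leaves the size open) on this scale. For compound 4 the estimated value is 200000 nM, with an expected range from 90000 nM to 400000 nM in this assay, and a reading reported only as a limit is quite possible.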

Compound 4, half-maximal cytotoxic concentration: > 200000 nM
Compound 4 ended at the assay's limit; the forecaster's own chance of this, stated with the estimate: 65%; the middle value lies on the limit itself.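

Compound 1 and compound 4 both read as limits of the assay and not as numbers, so no step can be read between them: the limit of > 200000 nM in this assay, at which 3 of the 4 values shown sit.

The compounds shown leave open whether cyano in place of formyl changes the reading at all, and how far either compound lies beyond the limit.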